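This account rests on a few compounds, and the source may have more. Where it says the series, first, only, none or still open, it means among the compounds named here.

Values in an in vivo ADME assay on the whole organism for pharmacokinetics, with Rattus norvegicus as the target, read by LC-MS, at a dose of 3 mg/kg by the oral route (on this read-out higher numbers stand for higher exposure at the dose given and lower numbers for lower exposure), are as follows

Compound 1 `Cc1cc(-c2n[nH]c(-c3ccnc(C#N)c3)n2)ccn1` gives 15100 nM
Compound 2 `COc1cc(-c2nc(-c3ccnc(C#N)c3)n[nH]2)ccn1` gives 719 nM

Compound 2 stands at the lower of the two values, and compound 1 lies above it by more than the usual scatter. The next compound, compound 3 `N#Cc1cc(-c2n[nH]c(-c3ccnc(Cl)c3)n2)ccn1`, has chloro in place of methoxy on an aromatic carbon, next to the ring nitrogen (chloro in place of methoxy on an aromatic carbon). For the measured compounds named here, no measured pair shows this change, so its size can only be estimated. Going by the values given here, the one guide is that compound 1 reaches 15100 nM, which shows how far above compound 2 a value can lie in this small set. A rise beyond the scatter is expected, though smaller than that gap. The expected move is a 3.5-fold higher number from compound 2 to compound 3 (0.54 log units; beyond the scatter), an estimate with wide uncertainty. Compound 3 is estimated at 2500 nM, with an expected range of 600 nM to 10000 nM.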

Compound 3, maximal plasma concentration: 18900 nM
For compound 3 the middle estimate is 7.6-fold (0.88 log units) below the measured one; measured number outside the range, above it.
By their numbers in this assay, from the lowest: compound 2; then compounds 1 and 3 (each within the scatter of the next).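

In this assay, chloro in place of methoxy on an aromatic carbon, next to the ring nitrogen, gives a 26-fold higher number from compound 2 to compound 3 (1.42 log units; beyond the scatter), so a change of one small group at this position can shift exposure strongly. For the compounds shown here, compound 3 at 18900 nM lies within the scatter of compound 1 at 15100 nM, which leaves methoxy as the one group of the three at this position with a clearly lower value. The data shown offer no measured explanation for this step.

The compounds shown leave open whether the low value is peculiar to methoxy or would also appear with ethoxy or an amine at this position. They also leave open whether fluoro or trifluoromethyl would match chloro and methyl.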